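Replacing Acetyl with Chlorophenyl: Expected Cytotoxicity Shift

This account rests on a few compounds, and the source may have more. Where it says the series, first, only, none or still open, it means among the compounds named here.

Compound 1, `Cc1cc(C)c(Oc2cc(Nc3ccc(C#N)cc3)ncc2C(=O)NCc2cn(Cc3ccccc3[N+](=O)[O-])nn2)c(C)c1`: > 212000 nM, a limit of the assay rather than a number.
Compound 2, `Cc1cc(C)c(Oc2cc(Nc3ccc(C#N)cc3)ncc2C(=O)NCc2cn(CC(N)=O)nn2)c(C)c1`: 24000 nM.
Compound 3, `CC(=O)Cn1cc(CNC(=O)c2cnc(Nc3ccc(C#N)cc3)cc2Oc2c(C)cc(C)cc2C)nn1`: 19400 nM.

These three share one core and differ only in the group on a saturated chain carbon bound to an aromatic nitrogen. All were tested in an ADME assay on MT4 cells (Homo sapiens) for cytotoxicity, read by MTT assay, with a stated time of 5 days; a higher number here means that more compound is tolerated, a lower number that less compound is tolerated. Compound 1 gives > 212000 nM, which is a limit of the assay and not a number. Compound 2 gives 24000 nM. Compound 3 gives 19400 nM, which sits within the usual scatter of compound 2, so the two cannot be told apart.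

Compound 4, `Cc1cc(C)c(Oc2cc(Nc3ccc(C#N)cc3)ncc2C(=O)NCc2cn(Cc3ccc(Cl)cc3)nn2)c(C)c1`, has not been measured. It differs from compound 3 in one place: 4-chlorophenyl in place of acetyl on a saturated chain carbon bound to an aromatic nitrogen. Among the compounds with values here, two measured steps bear on this. an at least 10-fold lower number from compound 1 to compound 3 (1.03 log units; beyond the scatter) and an at least 8.8-fold lower number from compound 1 to compound 2 (0.94 log units; beyond the scatter) both describe exchanging an aromatic ring on that chain carbon for a small carbonyl group, and each lowered the number beyond the scatter. By contrast, a 1.2-fold lower number from compound 2 to compound 3 (0.09 log units; within the scatter) lies within the scatter. Compound 4 runs the aromatic exchange the other way, putting a ring back on the chain carbon, so a higher number is expected, possibly again only a limit. The estimate for compound 4 is 80000 nM, between 25000 nM and 250000 nM. This corresponds to an expected step of a 4.1-fold higher number from compound 3 to compound 4 (0.62 log units; beyond the scatter).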

Compound 4, half-maximal cytotoxic concentration: >= 120000 nM
Compound 4: no number, only a limit (the forecaster's own chance of this, stated with the estimate: 35%); at least 1.5-fold (0.17 log units) between middle value and limit.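

Putting a ring back on the saturated chain carbon bound to an aromatic nitrogen gives, in this assay, an at least 6.1-fold higher number from compound 3 to compound 4 (0.79 log units; beyond the scatter) and an at least 5.0-fold higher number from compound 2 to compound 4 (0.69 log units; beyond the scatter). The high numbers are therefore not tied to the 2-nitrophenyl of compound 1, since 4-chlorophenyl in compound 4 also separates clearly from the acetyl of compound 3 and the carbamoyl of compound 2. Compound 4 ends at a limit of the assay, as compound 1 does, so the step between them cannot be read: the limit of >= 120000 nM in this assay, at which 1 of the 4 values shown sits.

From the compounds shown here alone, how much compound is tolerated at the top of this series therefore stays unknown. A plain phenyl without chlorine, or a longer carbon chain with no ring, on that carbon would show whether the ring itself or its substituent goes with the higher numbers.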